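The source may hold more compounds than are shown below. What is called first, only, known or untested is meant among the compounds shown, and "the series" means these compounds.

Compound 2 `C=C(Br)C(=O)Nc1ccc(C(=O)/C=C/c2ccc(OC)c(OC)c2OC)cc1` shows the lower of the two numbers measured in a functional assay on L1210 cells (Mus musculus) for antiproliferative activity, with a stated time of 48 h (a higher number here means a weaker inhibitor, a lower number a stronger inhibitor), giving 630 nM, while compound 1 `C=C(Br)C(=O)Nc1ccc(C(=O)/C=C/c2ccc(OC)c(OC)c2)cc1` gives 1300 nM in this assay. For the measured compounds named here, the only measured step, a 2.1-fold lower number from compound 1 to compound 2 (0.31 log units; beyond the scatter), concerns a methoxy on an aromatic carbon and is modest. Compound 3 `COc1ccc(/C=C/C(=O)c2ccc(N)cc2)c(OC)c1OC` differs from compound 2 in another place entirely: hydrogen in place of (1-bromoethenyl)carbonyl on a nitrogen on an aromatic ring. Going by the values given here, no measured step touches this nitrogen, so nothing in the data sets the size of the effect; the step from compound 1 to compound 2 is simply uninformative here. The group that leaves is a sizeable piece of compound 2, and removing so much from a compound is judged more likely to raise the number than to lower it. Compound 3 is therefore expected to show a weaker result, around 5000 nM, within 1000 nM to 30000 nM, which corresponds to an expected step of a 7.9-fold higher number from compound 2 to compound 3 (0.90 log units; beyond the scatter).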

Compound 3, half-maximal inhibitory concentration: 25000 nM
The estimate for compound 3 lay 5.0-fold (0.70 log units) below the measured number; measured number inside the range.
By their numbers in this assay, from the lowest: compound 2; then compound 1; then compound 3.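

In this assay, the nitrogen on the aromatic ring now has a measured step: hydrogen in place of (1-bromoethenyl)carbonyl gives a 40-fold higher number from compound 2 to compound 3 (1.60 log units; beyond the scatter) and is large. The earlier methoxy change, a 2.1-fold lower number from compound 1 to compound 2 (0.31 log units; beyond the scatter), was modest, so among these compounds the group on this nitrogen counts for much more than that methoxy on an aromatic carbon. Nothing given here accounts for the size of the nitrogen step.

The compounds shown leave open which part of the (1-bromoethenyl)carbonyl matters: whether an acetyl, an acryloyl without the bromine or a chloroacetyl on the same nitrogen would stay near compound 2 or move towards compound 3. They also leave open whether the nitrogen step would be of similar size with the methoxy pattern of compound 1.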